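Shrinking the Amine Ring of a Nicotinic Ligand

A few compounds are considered here, and "the series" means these few. Any claim that something is new, unique, unknown or untested is made for them only; others in the source may bear on it.

Measured compounds:
Compound 1 `CN1CCCC1COc1cnc(Cl)c(/C=C/c2ccncc2)c1` gives 0.028 nM in an assay for binding affinity to Neuronal acetylcholine receptor; alpha4/beta2 (Rattus norvegicus); a lower number here means a stronger inhibitor, a higher number a weaker inhibitor.
Compound 2 `CN1CCCC1COc1cnc(Cl)c(/C=C/c2cccnc2)c1` gives 0.088 nM in this assay.
Compound 3 `CN1CCCC1COc1cnc(Cl)c(/C=C/c2ccccn2)c1` gives 0.265 nM in this assay.

These three compounds share one core and differ only in which pyridyl group sits on the double-bonded chain carbon. Compound 1 has the lowest number of the three, and its lead is beyond the scatter in both directions: a 3.1-fold higher number from compound 1 to compound 2 (0.50 log units; beyond the scatter) and a 9.5-fold higher number from compound 1 to compound 3 (0.98 log units; beyond the scatter). The remaining step, a 3.0-fold higher number from compound 2 to compound 3 (0.48 log units; beyond the scatter), completes the ordering, so compound 1 is the strongest binder of the measured set.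

Compound 4 `CN1CCC1COc1cnc(Cl)c(/C=C/c2ccncc2)c1` keeps the pyridin-4-yl group of compound 1 and alters the other end of the molecule instead: a group of 5 heavy atoms (4 carbon, 1 nitrogen; one four-membered non-aromatic ring with 1 hetero atom) in place of a group of 6 heavy atoms (5 carbon, 1 nitrogen; one five-membered non-aromatic ring with 1 hetero atom), on a saturated chain carbon bound to an oxygen on an aromatic ring. Among the compounds with values here, none of the measured steps touches this part of the structure; all three swap the pyridyl group and say nothing about the ring carrying the nitrogen. Within the data shown here, there is therefore no measured step that bears on this change, and the expectation rests only on compound 1 as the starting point. With no evidence for a shift either way, the expected step is a 1.1-fold higher number from compound 1 to compound 4 (0.03 log units; within the scatter), essentially none beyond the scatter. The estimate for compound 4 is 0.03 nM, with a range from 0.008 nM to 0.12 nM.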

Compound 4, inhibition constant: 0.072 nM
For compound 4 the middle estimate is 2.4-fold (0.38 log units) below the measured one, within the range that was stated.
By their numbers in this assay, from the lowest: compound 1; then compounds 4 and 2 (each within the scatter of the next); then compound 3.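

Within the data shown here, until this point, every measured step had swapped the pyridyl group, so compound 4 gives the first reading at the other end of the molecule, the group on the saturated chain carbon bound to an oxygen on an aromatic ring. In this assay, replacing 1-methylpyrrolidin-2-yl with the four-membered ring gives a 2.6-fold higher number from compound 1 to compound 4 (0.41 log units; beyond the scatter), so this position responds to a change in ring size, although the step is modest and compound 4 still binds strongly at 0.072 nM. No available evidence explains why the four-membered ring gives a higher number than the five-membered ring.

Going by these compounds, this ring change has been read only with the pyridin-4-yl group in place, so it remains open whether a step of similar size would appear with the pyridin-3-yl or pyridin-2-yl group. The compounds shown also leave open how a larger piperidine ring, or an ethyl group in place of the methyl group on the ring nitrogen, would fare at the same position.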